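Two sulfonamides measured, a third awaiting its number

This account rests on a few compounds, and the source may have more. Where it says the series, first, only, none or still open, it means among the compounds named here.

Measured so far:
- compound 1, `CC1CCN(C2CCN(S(=O)(=O)c3ccc(F)cc3F)CC2)CC1`: 102 nM
- compound 2, `COc1ccccc1-c1ccc(S(=O)(=O)N2CCC(N3CCC(C)CC3)CC2)cc1`: 26 nM

In a functional assay on DLD-1 cells (Homo sapiens) for antiproliferative activity, read by CellTiter-Glo, with a stated time of 72 h (a lower number here means a stronger inhibitor, a higher number a weaker inhibitor), compound 1 gives 102 nM, the higher of the two numbers seen so far, and so the weaker inhibitor. Compound 2, which carries a different aryl group on the same shared core, gives 26 nM in this assay, a gap that lies beyond the usual scatter.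

Compound 3, `CC1CCN(C2CCN(S(=O)(=O)c3cc(Cl)cc(Cl)c3)CC2)CC1`, has not yet been measured. It differs from compound 1 in one place: 3,5-dichlorophenyl in place of 2,4-difluorophenyl on a sulfonyl sulfur. Both groups are halogenated phenyl rings of the same heavy-atom count, so the shape of the change is modest. Among the compounds with values here, with no measured pair of this kind to lean on, the expected step in this assay from compound 1 is small, slightly toward a lower number but possibly within the scatter: a 1.5-fold lower number from compound 1 to compound 3 (0.16 log units; within the scatter). Compound 3 is therefore estimated at 70 nM in this assay, with a likely range from 20 nM to 300 nM.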

Compound 3, half-maximal inhibitory concentration: 3400 nM
For compound 3 the middle estimate is 49-fold (1.69 log units) below the measured one; the measured number lies above the stated range.
By their numbers in this assay, from the lowest: compound 2; then compound 1; then compound 3.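

This position on the sulfonyl sulfur proves far from forgiving in this assay: replacing 2,4-difluorophenyl with 3,5-dichlorophenyl gives a 33-fold higher number from compound 1 to compound 3 (1.52 log units; beyond the scatter) and makes compound 3 a much weaker inhibitor. The two groups have the same count of 8 heavy atoms, the same single aromatic ring, no hydrogen-bond donors or acceptors and no net charge, so these counts alone do not tell them apart in this assay. Nothing available explains the loss.

This one step changes both the halogen and where it sits on the ring, so the two changes cannot be separated; 2,4-dichlorophenyl or 3,5-difluorophenyl on the same sulfonyl sulfur would tell them apart. On these data alone, how plain phenyl, with no halogen, would compare with compound 1 and compound 3 also stays open.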